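The source may report more compounds than this note shows. Statements on the series, on what has been measured and on what is new or still open speak of the compounds shown alone.

Notes on the series, read in an ADME assay on KB cells (Homo sapiens) for cytotoxicity, with a stated time of 48 h; on this read-out higher numbers stand for weaker inhibition and lower numbers for stronger inhibition. Compound 1 (`C=C1[C@H](C)CCC[C@]1(C)CC/C(C)=C/CC1=C(O)C(=O)C=C(N[C@@H](C(=O)O)[C@H](C)O)C1=O`) gives > 10 ug/mL, a limit of the assay. Compound 2 (`C=C1[C@H](C)CCC[C@]1(C)CC/C(C)=C/CC1=C(O)C(=O)C=C(N[C@H](C(=O)O)[C@@H](C)O)C1=O`) gives > 10 ug/mL, also a limit. Compound 3 (`C=C1[C@H](C)CCC[C@]1(C)CC/C(C)=C/CC1=C(O)C(=O)C=C(N[C@@H](C(=O)O)[C@@H](C)O)C1=O`) gives > 10 ug/mL, again a limit, so it has no number of its own. The three compounds share (the limit of > 10 ug/mL in this assay, at which 3 of the 3 values shown sit).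

Compound 4 (`C=C1[C@H](C)CCC[C@]1(C)CC/C(C)=C/CC1=C(O)C(=O)C=C(NCC(=O)O)C1=O`) carries hydrogen in place of 1-hydroxyethyl on a saturated chain carbon bound to an amine nitrogen and a carbonyl carbon.

Three measured steps lie nearest to this change: a step that the two limits leave unreadable from compound 1 to compound 2, a step that the two limits leave unreadable from compound 1 to compound 3 and a step that the two limits leave unreadable from compound 2 to compound 3. None has a readable size. They concern (the fact that compounds 1 and 2 differ only in the configuration as drawn), the fact that compounds 1 and 3 differ only in the configuration as drawn and (the fact that compounds 2 and 3 differ only in the configuration as drawn), so none of them removes the group that leaves in compound 4. They therefore give no size to carry over, and no direction can be argued from them.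

In this assay the working expectation is that the series stays where it stands, with compound 3 as the anchor at > 10 ug/mL, a limit. The expected step is a step that the limit leaves unreadable from compound 3 to compound 4, with no shift beyond the scatter estimated. For compound 4 the estimate is 15 ug/mL, with an expected range of 6 ug/mL to 30 ug/mL, and a report as a limit is likely.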

Compound 4, half-maximal inhibitory concentration: 4 ug/mL
Compound 4: middle estimate off by 3.8-fold (0.57 log units), on the high side; the whole stated range lies above it.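

In this assay, the saturated chain carbon bound to an amine nitrogen and a carbonyl carbon now shows a readable effect: hydrogen in place of 1-hydroxyethyl gives an at least 2.5-fold lower number from compound 3 to compound 4 (0.39 log units; beyond the scatter), and the same change gives an at least 2.5-fold lower number from compound 2 to compound 4 (0.39 log units; beyond the scatter) and an at least 2.5-fold lower number from compound 1 to compound 4 (0.39 log units; beyond the scatter). The steps among compound 1, compound 2 and compound 3 cannot be read, so those compounds showed only that all three configurations as drawn sit at the assay limit. Compound 4 gives a number of its own, 4 ug/mL. Each new step starts from a limit and so fixes a direction and a smallest size, and that direction holds from all three configurations.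

The compounds shown leave open whether the lower number follows from losing the whole 1-hydroxyethyl group or only its hydroxyl, a question that a methyl or ethyl group at the same place would separate. They also leave open how much the carboxyl group of the (carboxymethyl)amino chain contributes, which a methyl ester or primary amide in its place would test.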